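The source may report more compounds than this note shows. Statements on the series, on what has been measured and on what is new or still open speak of the compounds shown alone.

Measured in a functional assay (trachea) with Cavia porcellus as the target; on this read-out higher numbers stand for an effect only at larger amounts of compound and lower numbers for an effect already at smaller amounts:

- compound 1 `CCCn1c(=O)n(CC(=O)O)c(=O)c2[nH]cnc21`: 41000 nM
- compound 2 `CCCn1c(=O)n(CCOC)c(=O)c2[nH]cnc21`: 700 nM

Of these two measured compounds, compound 2 has the lower number, at 700 nM, and compound 1 stands well above it. The next compound, compound 3 `CCCn1c(=O)n(CCCOC)c(=O)c2[nH]cnc21`, keeps the shared core and alters only the chain that carries the ether. The difference is methoxymethyl in place of methoxy on a saturated chain carbon, two bonds along the chain from an aromatic nitrogen. In words, methoxymethyl takes the place of methoxy on a saturated chain carbon, two bonds along the chain from an aromatic nitrogen, so that 2-methoxyethyl becomes 3-methoxypropyl.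

Within the data shown here, only one measured step exists, a 59-fold lower number from compound 1 to compound 2 (1.77 log units; beyond the scatter). It is large and beyond the scatter, but it exchanges carboxy for methoxymethyl, which is a different change from this one. It therefore bears on the new change only loosely, and it sets neither a size nor a direction. Among the measured compounds shown here, the data hold no measured example of extending this ether chain. In this assay, no step beyond the scatter is expected, and the expected step is a 1.1-fold higher number from compound 2 to compound 3 (0.06 log units; within the scatter). The estimate for compound 3 is 800 nM, with an expected range from 280 nM to 2300 nM.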

Compound 3, half-maximal effective concentration: 2900 nM
The estimate for compound 3 lay 3.6-fold (0.56 log units) below the measured number; measured number above the stated range.
By their numbers in this assay, from the lowest: compound 2; then compound 3; then compound 1.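

In this assay, this position responds even to a small extension of the ether chain: 3-methoxypropyl in place of 2-methoxyethyl gives a 4.1-fold higher number from compound 2 to compound 3 (0.62 log units; beyond the scatter) and so a modest step beyond the scatter, which shows that the length of the chain counts here, something the exchange of carboxy alone could not show. Among these compounds, the move away from carboxy still holds with the longer ether, with a 14-fold lower number from compound 1 to compound 3 (1.15 log units; beyond the scatter) as a large step, so that both ether chains stand clearly apart from the carboxy compound, while 2-methoxyethyl remains the one with the lowest number of the three. Nothing at hand explains why this one extension shifts the number as it does.

With only two ether chains compared, a single step cannot show whether a longer chain such as 4-methoxybutyl would continue in the same direction, or whether a shorter methoxymethyl would reverse it. On these data alone, it also remains open whether the ether oxygen matters at all, which a plain butyl chain would test, and how an amine at the end of the chain would compare with the ethers.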